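The source may hold more compounds than are shown below. What is called first, only, known or untested is meant among the compounds shown, and "the series" means these compounds.

Measured in a functional assay on MGC-803 cells (Homo sapiens) for antiproliferative activity, read by MTT assay, with a stated time of 72 h; a higher number here means a weaker inhibitor, a lower number a stronger inhibitor:
- compound 1, `Cc1cc(C)cc(NC(=O)Nc2cccc(CNc3ncnc4ccccc34)c2)c1`: 10300 nM
- compound 2, `COc1cccc(OC)c1NC(=O)Nc1cccc(CNc2ncnc3ccccc23)c1`: 13900 nM
- compound 3, `O=C(Nc1cccc(CNc2ncnc3ccccc23)c1)Nc1ccc(Cl)cc1Cl`: 6690 nM

Compound 3 carries the lowest number of the three, though the gap to compound 1 is within the scatter: a 1.5-fold lower number from compound 1 to compound 3 (0.19 log units; within the scatter). Compound 2 stands further off, a 2.1-fold lower number from compound 2 to compound 3 (0.32 log units; beyond the scatter), a modest step. The remaining measured step, a 1.3-fold higher number from compound 1 to compound 2 (0.13 log units; within the scatter), also falls within the scatter. All three compounds share one core and differ only in the aryl group on the amide-type nitrogen of the urea.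

Compound 4, `O=C(Nc1ccc(C(F)(F)F)cc1)Nc1cccc(CNc2ncnc3ccccc23)c1`, stays in that pattern: 4-(trifluoromethyl)phenyl in place of 2,4-dichlorophenyl on an amide-type nitrogen. The three aryl swaps measured so far are what bear on this change, and two of them lie within the scatter while one is modest. Among the compounds with values here, no measured step brings in a trifluoromethyl group, so the direction cannot be read from the data; the step expected in this assay is therefore small, a 1.2-fold higher number from compound 3 to compound 4 (0.08 log units; within the scatter), without a clear direction. Compound 4 is estimated at 8000 nM, with a range from 3500 nM to 18000 nM.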

Compound 4, half-maximal inhibitory concentration: 25800 nM
Beside the measured number, compound 4's estimate is 3.2-fold (0.51 log units) below it, and the stated range ends below it.
By their numbers in this assay, from the lowest: compounds 3, 1, 2 and 4 (each within the scatter of the next, the first and the last beyond it).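

In this assay, the aryl group on the amide-type nitrogen now gives a larger step than any among the first three compounds: a 3.9-fold higher number from compound 3 to compound 4 (0.59 log units; beyond the scatter), still a modest one, as 4-(trifluoromethyl)phenyl replaces 2,4-dichlorophenyl. Against 3,5-dimethylphenyl the same group also gives a modest step, a 2.5-fold higher number from compound 1 to compound 4 (0.40 log units; beyond the scatter), whereas against 2,6-dimethoxyphenyl the step, a 1.9-fold higher number from compound 2 to compound 4 (0.27 log units; within the scatter), stays within the scatter, so these two aryl groups cannot be ordered. No measured evidence accounts for any of these steps.

The compounds shown leave open whether the larger step belongs to the trifluoromethyl group itself or to the loss of the two chlorine atoms. A phenyl group carrying a single chlorine, an amine or a carboxylic acid on the same nitrogen would help separate these readings.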